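Chloro for methyl: expected cytotoxicity of compound 3

This account rests on a few compounds, and the source may have more. Where it says the series, first, only, none or still open, it means among the compounds named here.

In a functional assay on MT4 cells (Homo sapiens) for cytotoxicity (on this read-out higher numbers stand for weaker inhibition and lower numbers for stronger inhibition), compound 1 `Cc1ccc(Sc2cccc(N)c2C#N)cc1` gives > 200000 nM as a limit, not a number. Compound 2 `Cc1cc(C)cc(Sc2cccc(N)c2C#N)c1` gives > 2000 nM as a limit too, so its standing is bounded on one side only. Compound 3 `Cc1cc(Cl)cc(Sc2cccc(N)c2C#N)c1` carries chloro in place of methyl on an aromatic carbon. Among the compounds with values here, no measured step covers this change, so the expectation stays loose: an estimated step that the limit leaves unreadable from compound 2 to compound 3 toward weaker inhibition is expected in this assay for this swap. Compound 3 is estimated at 20000 nM with an expected range from 2000 nM to 200000 nM and may return only a limit.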

Compound 3, half-maximal inhibitory concentration: 16000 nM
The estimate for compound 3 lay 1.3-fold (0.10 log units) above the measured number; measured number inside the range.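

Within the data shown here, compound 2 stands only as a limit, > 2000 nM, so no step from compound 2 to compound 3 can be read. On these data alone, the size and direction of the effect of chloro in place of methyl on an aromatic carbon in this assay stay open.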